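Shortening the Amide Chain on a Shared Core

The source may report more compounds than this note shows. Statements on the series, on what has been measured and on what is new or still open speak of the compounds shown alone.

Compound 1 `CCCCNC(=O)C1C(C(=O)O)[C@@H]2CC[C@H]1O2` and compound 2 `CCCCCCCCCCNC(=O)C1C(C(=O)O)[C@@H]2CC[C@H]1O2` share one core and differ only in the length of the chain attached to the amide-type nitrogen. In an ADME assay on HT-29 cells (Homo sapiens) for cytotoxicity, read by MTT assay, with a stated time of 72 h (a lower number here means a stronger inhibitor of growth, a higher number a weaker inhibitor of growth), compound 1 gives 10000 nM. In this assay compound 2 gives 10000 nM. The step of no change at the digits printed from compound 1 to compound 2 (within the scatter) shows that hexyl in place of hydrogen on a saturated chain carbon, four bonds along the chain from an amide-type nitrogen, left the read-out where it was. Compound 2 therefore stands level with compound 1 on the numbers at hand, and neither can be called the stronger.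

Compound 3 `CCCNC(=O)C1C(C(=O)O)[C@@H]2CC[C@H]1O2` is the next member of the set. The change from compound 2 to compound 3 is hydrogen in place of heptyl on a saturated chain carbon, three bonds along the chain from an amide-type nitrogen. Among the measured compounds shown here, only one measured step bears on this kind of change, the lengthening of the same chain, and that step, no change at the digits printed from compound 1 to compound 2 (within the scatter), produced no movement. A shorter chain on the same kind of carbon is expected to behave alike, so the expected step is no change at the digits printed from compound 2 to compound 3 (within the scatter), nothing beyond the scatter. Compound 3 is estimated at 10000 nM, within a range from 5000 nM to 20000 nM.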

Compound 3, concentration for 50% growth inhibition: 10000 nM
Estimate against measurement, compound 3: no gap at the digits printed; low and high end bracket the measured number.
By their numbers in this assay, from the lowest: compounds 1, 2 and 3 (each within the scatter of the next).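

In this assay the chain on the amide-type nitrogen is now also cut back, at a saturated chain carbon three bonds along from that nitrogen: hydrogen in place of heptyl gives no change at the digits printed from compound 2 to compound 3 (within the scatter) and hydrogen in place of methyl gives no change at the digits printed from compound 1 to compound 3 (within the scatter) as well. The earlier pair showed only the addition of hexyl at a carbon four bonds along the chain, so these steps add a second place and the opposite kind of change, and across these three compounds neither the removal of heptyl nor that of methyl shifts the read-out beyond the scatter. No measured evidence is available to explain this flat result.

Going by these compounds, all three compounds carry plain saturated chains on the amide-type nitrogen, so it remains open whether an amine or a hydroxyl group at the end of the chain, or a phenyl ring in its place, would give a different number. Among the compounds shown here, it also remains open whether a chain longer than the one in compound 2 would separate from this set.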